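The compounds below may be only part of what the source reports. "The series", "measured", "known", "first", "only" and "open" are said of these compounds alone.

Of the compounds shown here, three built on one shared core have been measured in an ADME assay (liver) for metabolic stability, with Liver microsome (Rattus norvegicus) as the target, using microsomes and NADPH, with a stated time of 30 min; a higher number here means faster removal of the compound, a lower number slower removal. Compound 1, `CC#C[C@H]1CN(S(=O)(=O)c2ccc(N)nc2)CCN1c1ccc([C@@](O)(CO)C(F)(F)F)cc1`, gives 53 mL.min-1.g-1. Compound 2, `CC#C[C@H]1CN(S(=O)(=O)c2ccc(N)nc2)CCN1c1ncc(C(C)(O)C(F)(F)F)s1`, gives 87 mL.min-1.g-1, and compound 3, `CC#C[C@H]1CN(S(=O)(=O)c2ccc(N)nc2)CCN1c1ncc(C(O)(C(F)(F)F)C(F)(F)F)cn1`, gives 28 mL.min-1.g-1. The number for compound 1 falls within the usual scatter of the number for compound 2 and also of the number for compound 3, so these three values do not separate from one another. Compound 4, `C#CCC(O)(c1ccc(N2CCN(S(=O)(=O)c3ccc(N)nc3)C[C@@H]2C#CC)cc1)C(F)(F)F`, has not yet been measured in this assay. It differs from compound 1 in one place: a group of 9 heavy atoms (5 carbon, 1 oxygen, 3 fluorine; no ring) in place of a group of 8 heavy atoms (3 carbon, 2 oxygen, 3 fluorine; no ring), on an aromatic carbon. Among the compounds with values here, no pair of measured compounds differing in a single place is available as a guide, so the expectation rests on compound 1 alone. In this assay the step expected is a 1.4-fold higher number from compound 1 to compound 4 (0.15 log units; within the scatter), small, upward and not beyond the scatter. Compound 4 is estimated at 75 mL.min-1.g-1, within a range from 35 mL.min-1.g-1 to 150 mL.min-1.g-1.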

Compound 4, intrinsic clearance in microsomes: 59 mL.min-1.g-1
Compound 4: middle estimate off by 1.3-fold (0.10 log units), on the high side; the range from low to high includes it.
By their numbers in this assay, from the lowest: compounds 3, 1, 4 and 2 (each within the scatter of the next, the first and the last beyond it).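

In this assay, within the data shown here, the first comparison at this aromatic carbon that changes one place only gives a 1.1-fold higher number from compound 1 to compound 4 (0.05 log units; within the scatter) and so does not separate the two compounds. At this position, the group of 9 heavy atoms with its triple bond and the group of 8 heavy atoms cannot be told apart by this read-out. No measurement shown here offers an explanation for this result. Going by these compounds, whether an amine, a carboxylic acid or a longer chain at this place would give a number beyond the scatter remains open. So does whether the same change would behave alike on the rings of compound 2 and compound 3.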